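A few compounds are considered here, and "the series" means these few. Any claim that something is new, unique, unknown or untested is made for them only; others in the source may bear on it.

In an ADME assay on NIH3T3 cells (Mus musculus) for inhibition, read by MTT assay, with a stated time of 48 h (a lower number here means a stronger inhibitor, a higher number a weaker inhibitor), compound 1 `COc1ccc(-c2nc3ccccn3c2Sc2ccccc2)cc1` stands at 91700 nM and sits level with compound 2 `CS(=O)(=O)c1ccc(-c2nc3ccccn3c2Sc2cccc3ccccc23)cc1` at 86400 nM and compound 3 `Clc1ccc(Sc2c(-c3cccs3)nc3ccccn23)cc1` at 86100 nM (all three lie within the usual scatter of one another). Compound 4 `Clc1ccc(-c2nc3ccccn3c2Sc2ccccc2)cc1` differs from compound 1 by chloro in place of methoxy on an aromatic carbon, para to a large group (chloro in place of methoxy on an aromatic carbon). Going by the values given here, no measured pair isolates this change. Compound 3 also holds a chloro group and gives 86100 nM in the same range, so no step beyond the scatter is expected in this assay here. The estimated change is a 1.1-fold lower number from compound 1 to compound 4 (0.03 log units; within the scatter) and stays within the scatter. Compound 4 is expected at 85000 nM with 45000 nM to 140000 nM as the estimated range.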

Compound 4, half-maximal inhibitory concentration: > 100000 nM
Compound 4 was reported as a limit; the forecaster's own chance of this, stated with the estimate: 15%; middle value at least 1.1-fold (0.07 log units) away from the limit.
By their numbers in this assay, from the lowest: compounds 3, 2 and 1 (each within the scatter of the next). At a limit, above all of these: compound 4.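

In this assay, going by these compounds alone, the change from 4-methoxyphenyl to 4-chlorophenyl gives the first step read at a single place: an at least 1.0-fold higher number from compound 1 to compound 4 (0.03 log units; that floor lies within the scatter). The value of compound 4, > 100000 nM, is a limit and not a number. Chloro in place of methoxy on this aromatic carbon gives no sign of stronger inhibition, and the reading stands at the edge of the assay: the limit of > 100000 nM in this assay, at which 1 of the 4 values shown sits.

On these data alone, how far compound 4 really lies past its limit stays open. So does whether an amine or a carboxylic acid at this place would move the number clear of the scatter.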